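The source may hold more compounds than are shown below. What is called first, only, known or untested is meant among the compounds shown, and "the series" means these compounds.

Measured in a functional assay on MDA-MB-231 cells (Homo sapiens) for antiproliferative activity, read by sulforhodamine B assay, with a stated time of 72 h; on this read-out lower numbers stand for stronger inhibition and higher numbers for weaker inhibition:
compound 1, `Fc1ccc(/C=C/c2cc3ccccc3nc2Cl)cc1`: > 50000 nM, a limit of the assay rather than a number (the limit of > 50000 nM in this assay, at which 1 of the 3 values shown sits).
compound 2, `COc1ccc2nc(Cl)c(/C=C/c3ccc(F)cc3)cc2c1`: 11000 nM.
compound 3, `FC(F)(F)c1cccc(/C=C\c2cc3ccccc3nc2Cl)c1`: 3750 nM.

Compound 4, `COc1ccc2nc(Cl)c(/C=C\c3cccc(C(F)(F)F)c3)cc2c1`, is not yet measured. Between the two measured numbers, compound 3 shows the lower one. The step of an at least 4.5-fold lower number from compound 1 to compound 2 (0.65 log units; beyond the scatter) is methoxy in place of hydrogen on an aromatic carbon. Compound 4 carries the same change on compound 3, (methoxy in place of hydrogen on an aromatic carbon); the two place descriptions agree word for word. How the core of compound 3 differs from that of compound 1 is not broken down here. Because the earlier step of an at least 4.5-fold lower number from compound 1 to compound 2 (0.65 log units; beyond the scatter) rests on a limit for compound 1 (the limit of > 50000 nM in this assay, at which 1 of the 3 values shown sits), only its lower bound is known. For compound 4 a step of comparable size, a 4.2-fold lower number from compound 3 to compound 4 (0.62 log units; beyond the scatter), is expected in this assay. Compound 4 is accordingly estimated at 900 nM, between 250 nM and 3000 nM.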

Compound 4, half-maximal inhibitory concentration: 3280 nM
Compound 4: middle estimate off by 3.6-fold (0.56 log units), on the low side, and the stated range ends below it.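

In this assay, methoxy in place of hydrogen on an aromatic carbon gives a 1.1-fold lower number from compound 3 to compound 4 (0.06 log units; within the scatter), so on the core of compound 3 the change does not stand out from the scatter. The change therefore does not carry over at the same size from one core to the other: the same change on two cores in this assay, an at least 4.5-fold lower number (0.65 log units; beyond the scatter) from compound 1 to compound 2 and a 1.1-fold lower number (0.06 log units; within the scatter) from compound 3 to compound 4, at least 3.9-fold (0.59 log units) apart, beyond the scatter of two such steps. The earlier step rests on a limit for compound 1, so only its lower bound is known, and these compounds do not show which difference between the cores goes with the gap: the limit of > 50000 nM in this assay, at which 1 of the 4 values shown sits.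

Open, as far as these compounds go, is whether an amine, a hydroxyl or a longer alkoxy chain on the same aromatic carbon would follow methoxy on either core. Also open, from the compounds shown here alone, is how methoxy would behave on a third core.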